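From cyclopentyl to 3-hydroxypropyl: working notes on compound 3

The compounds below may be only part of what the source reports. "The series", "measured", "known", "first", "only" and "open" are said of these compounds alone.

Results in a functional assay on MV4-11 cells (Homo sapiens) for antiproliferative activity, read by MTT assay; on this read-out lower numbers stand for stronger inhibition of growth and higher numbers for weaker inhibition of growth:
- Compound 1 `COc1ccc(Nc2nc(NCCCO)c3ccccc3n2)cc1`: 8750 nM
- Compound 2 `N#Cc1ccc(Nc2nc(NC3CCCC3)c3ccccc3n2)cc1`: "not determined" (no result reported)

For the measured compounds named here, compound 2 has no standing on the numbers: it was not determined, so it offers no starting value and no measured step exists. Compound 3 `N#Cc1ccc(Nc2nc(NCCCO)c3ccccc3n2)cc1` has yet to be measured in this assay. The change in question is 3-hydroxypropyl in place of cyclopentyl on a nitrogen on an aromatic ring. No size or direction can be expected for this step, as its starting point is missing. Going by the values given here, the only reference is compound 1, which carries the same (3-hydroxypropyl)amino group and gives 8750 nM. A result close to that value, with no clear shift beyond the scatter, is expected. For compound 3 the estimated value is 9000 nM, with an expected range from 3000 nM to 30000 nM.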

Compound 3, concentration for 50% growth inhibition: 2790 nM
The estimate for compound 3 lay 3.2-fold (0.51 log units) above the measured number; measured number outside the range, below it.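

In this assay, for the compounds shown here, with the 3-hydroxypropyl group on the nitrogen held constant, cyano in place of methoxy on an aromatic carbon gives a 3.1-fold lower number from compound 1 to compound 3 (0.50 log units; beyond the scatter), the first readable step. This shows that the read-out responds to the group on that aromatic carbon, although the evidence is a single pair. The step from compound 2 to compound 3 cannot be read, so the change from cyclopentyl to 3-hydroxypropyl still has no size or direction, and no available data explain the result with cyano.

The compounds shown leave open how the read-out responds when an amine or a carboxylic acid replaces the hydroxyl of the 3-hydroxypropyl group, or when a longer chain carries that hydroxyl. On these data alone, it also remains open whether the step from methoxy to cyano carries over to compounds with cyclopentyl on the nitrogen.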